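Pyrazole attachment point swap in a dihydropyrazole amide series

The source may report more compounds than this note shows. Statements on the series, on what has been measured and on what is new or still open speak of the compounds shown alone.

Compound 1 `O=C(c1cn[nH]c1)N1CCC(C(=O)N2N=CCC2c2ccccc2)CC1` is the best-characterised member of this set in an ADME assay on microsomes (Rattus norvegicus) for metabolic stability; a lower number here means that the compound disappears faster, a higher number that the compound lasts longer. In this assay compound 1 reaches only a limit, > 2.75 h, which is the ceiling described as the limit of > 2.75 h in this assay, at which 1 of the 3 values shown sits. Compound 2 `O=C(C1CCOCC1)N1N=CCC1c1ccccc1` likewise gives only a limit in this assay, > 1.5 h, corresponding to the limit of > 1.5 h in this assay, at which 1 of the 3 values shown sits. Compound 3 `O=C(C1CCC1)N1N=CCC1c1ccccc1` gives a measured number in this assay, 0.583 h. Within the data shown here, the one step that can be sized is an at least 2.5-fold lower number from compound 2 to compound 3 (0.41 log units; beyond the scatter); it concerns a different group on a different carbonyl carbon and so does not bear directly on the change at hand.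

Compound 4 `O=C(c1cc[nH]n1)N1CCC(C(=O)N2N=CCC2c2ccccc2)CC1` differs from compound 1 by 1H-pyrazol-3-yl in place of 1H-pyrazol-4-yl on a carbonyl carbon. Among the measured compounds shown here, no measured pair in this set alters the pyrazole, so there is nothing to size this change against. With the same atoms joined differently, compound 4 is expected to stay close to compound 1, an expected step that the limit leaves unreadable from compound 1 to compound 4, with the likely outcome again a limit rather than a number. The estimate for compound 4 in this assay is 3 h, within 1.2 h to 7 h.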

Compound 4, half-life: 0.317 h
For compound 4 the middle estimate is 9.5-fold (0.98 log units) above the measured one; measured number outside the range, below it.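

In this assay, the way the pyrazole is joined to this carbonyl carbon proves to matter: 1H-pyrazol-3-yl in place of 1H-pyrazol-4-yl gives an at least 8.6-fold lower number from compound 1 to compound 4 (0.93 log units; beyond the scatter), although the atoms are the same and are only joined differently. Among these compounds, the only earlier step concerned a different group on a different carbonyl carbon, so this is the first sign in the set that the attachment point of the pyrazole alone can shift the half-life. The size of this step has no upper bound, since it starts from a limit for compound 1: the limit of > 2.75 h in this assay, at which 1 of the 4 values shown sits.

What the compounds shown do not tell is why the attachment point has this effect. On these data alone, it also remains open whether an imidazole or a 1,2,3-triazole on the same carbonyl carbon would track compound 1 or compound 4.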